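Thiophen-2-yl for 2-phenylethenyl: an estimate of cytotoxicity

The source may hold more compounds than are shown below. What is called first, only, known or untested is meant among the compounds shown, and "the series" means these compounds.

Measured compounds:
compound 1 `CC(=O)OC[C@H]1O[C@@H](n2cc(CN3C(=O)/C(=C\C=C\c4ccccc4)c4ccccc43)nn2)[C@H](OC(C)=O)[C@@H](OC(C)=O)[C@@H]1OC(C)=O`: 25900 nM
compound 2 `CC(=O)OC[C@H]1O[C@@H](n2cc(CN3C(=O)/C(=C/C=C/c4ccccc4)c4ccccc43)nn2)[C@H](OC(C)=O)[C@@H](OC(C)=O)[C@@H]1OC(C)=O`: 12300 nM

In an ADME assay on NIH3T3 cells (Homo sapiens) for cytotoxicity, read by sulforhodamine B assay, with a stated time of 48 h (on this read-out higher numbers stand for weaker inhibition and lower numbers for stronger inhibition), compound 1 gives 25900 nM and compound 2 gives 12300 nM. Going by the values given here, compound 1 stands highest of the two numbers, with compound 2 nearest; the single measured step, a 2.1-fold lower number from compound 1 to compound 2 (0.32 log units; beyond the scatter), rests only on (the fact that compounds 1 and 2 differ only in the configuration as drawn). Compound 3 `CC(=O)OC[C@H]1O[C@@H](n2cc(CN3C(=O)/C(=C\c4cccs4)c4ccccc43)nn2)[C@H](OC(C)=O)[C@@H](OC(C)=O)[C@@H]1OC(C)=O` differs from compound 1 by thiophen-2-yl in place of 2-phenylethenyl on a double-bonded chain carbon bound to a double-bonded ring carbon. Among the compounds with values here, no measured step changes the group on that chain carbon, so the geometric step from compound 1 to compound 2 offers little guidance. For compound 3 no step beyond the scatter is expected in this assay: a 1.0-fold lower number from compound 1 to compound 3 (0.02 log units; within the scatter). Compound 3 is therefore estimated at 25000 nM, within a range from 8000 nM to 70000 nM.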

Compound 3, half-maximal inhibitory concentration: 14600 nM
Beside the measured number, compound 3's estimate is 1.7-fold (0.23 log units) above it, and the stated range covers the measured number.
By their numbers in this assay, from the lowest: compounds 2, 3 and 1 (each within the scatter of the next, the first and the last beyond it).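

In this assay, the place on a double-bonded chain carbon bound to a double-bonded ring carbon accepts a change of group and not only of geometry: thiophen-2-yl in place of 2-phenylethenyl gives a 1.8-fold lower number from compound 1 to compound 3 (0.25 log units; within the scatter). The exchange of a six-membered aromatic ring of carbon only, with its extra double bond, for a five-membered aromatic ring with a hetero atom therefore leaves the number within the scatter. Nothing on hand explains this step. On these data alone, whether an amine, a carboxylic acid or a longer chain at this place would likewise keep the number within the scatter remains open. So does the effect of the drawn double-bond geometry with thiophen-2-yl in place.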